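Biaryl amide series: oxadiazole in place of propylamino

The source may hold more compounds than are shown below. What is called first, only, known or untested is meant among the compounds shown, and "the series" means these compounds.

Measured so far:
compound 1 `C[C@@H]1CN(c2ncccc2C(F)(F)F)CCN1C(=O)Nc1ccc(C(F)(F)F)cc1`, 17 nM
compound 2 `Cc1cccnc1-c1ccc(C(=O)Nc2ccc(Cl)cc2)cc1`, 1500 nM
compound 3 `CCCNc1cccnc1-c1ccc(C(=O)Nc2ccc(C(C)(C)C)cc2)cc1`, 158 nM

In a functional assay for antagonist activity at transient receptor potential cation channel subfamily V member 1 (Homo sapiens), read by FLIPR (on this read-out higher numbers stand for weaker inhibition and lower numbers for stronger inhibition), compound 1 gives 17 nM and compound 2 gives 1500 nM. Compound 3 stands between them with 158 nM, well apart from each on either side. Compound 4 `Cc1nnc(-c2cccnc2-c2ccc(C(=O)Nc3ccc(C(C)(C)C)cc3)cc2)o1` is not yet measured; it differs from compound 3 in one place: 5-methyl-1,3,4-oxadiazol-2-yl in place of propylamino on an aromatic carbon. Within the data shown here, no measured pair shows this change, so its effect in this assay is open; the expectation is a step of modest size, none beyond the scatter, with the estimated step of a 1.1-fold lower number from compound 3 to compound 4 (0.02 log units; within the scatter) carrying wide uncertainty. For compound 4 the expected value in this assay is 150 nM, within 40 nM to 600 nM.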

Compound 4, half-maximal inhibitory concentration: 387 nM
Compound 4: the middle estimate sits 2.6-fold (0.41 log units) below what was measured, and the stated range covers the measured number.
By their numbers in this assay, from the lowest: compound 1; then compound 3; then compound 4; then compound 2.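

Replacing propylamino with 5-methyl-1,3,4-oxadiazol-2-yl gives a 2.4-fold higher number from compound 3 to compound 4 (0.39 log units; beyond the scatter) in this assay. Among these compounds, this is the first read on this position, two atoms from the ring nitrogen: the step is modest, and inhibition survives the loss of the chain. The change removes a hydrogen-bond donor and adds a ring in one move, so this single step does not separate the two, and no data here bear on the reason for it. Open, from the compounds shown here alone, is how butylamino, dimethylamino or an unmethylated oxadiazole would compare at this position. Also open, going by these compounds, is whether the step holds with chloro in place of tert-butyl.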